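The source may hold more compounds than are shown below. What is called first, only, known or untested is meant among the compounds shown, and "the series" means these compounds.

Working notes on the series. In a functional assay on T47D cells (Homo sapiens) for cytotoxicity, read by sulforhodamine B assay, with a stated time of 48 h (a lower number here means a stronger inhibitor, a higher number a weaker inhibitor), compound 1 `NS(=O)(=O)c1ccc(N/C=C\C(=O)c2cc3ccccc3oc2=O)cc1` gives 109000 nM. Compound 2 `CC(=O)NS(=O)(=O)c1ccc(N/C=C\C(=O)c2cc3ccccc3oc2=O)cc1` gives no result reported in this assay. Among the measured compounds shown here, compound 3 `O=C(/C=C\Nc1ccc(S(=O)(=O)Nc2ccccn2)cc1)c1cc2ccccc2oc1=O` gives 37600 nM in this assay, the lowest of the two numbers recorded, and the step of a 2.9-fold lower number from compound 1 to compound 3 (0.46 log units; beyond the scatter) is the only measured step in the set. Compound 4 `Nc1ccc(S(=O)(=O)c2ccc(N/C=C\C(=O)c3cc4ccccc4oc3=O)cc2)cc1` differs from compound 3 in that (4-aminophenyl in place of (pyridin-2-yl)amino on a sulfonyl sulfur). For the measured compounds named here, no measured step bears directly on this change; the single known step concerns a substituent on a sulfonamide nitrogen rather than a replacement on the sulfonyl sulfur, so it offers little guidance. The expected step for compound 4 is therefore a 1.1-fold higher number from compound 3 to compound 4 (0.03 log units; within the scatter), not clearly beyond the scatter. The estimate for compound 4 is 40000 nM, with a range from 12000 nM to 130000 nM.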

Compound 4, half-maximal inhibitory concentration: 91900 nM
Compound 4: middle estimate off by 2.3-fold (0.36 log units), on the low side, within the range that was stated.
By their numbers in this assay, from the lowest: compound 3; then compounds 4 and 1 (each within the scatter of the next).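

The step of a 2.4-fold higher number from compound 3 to compound 4 (0.39 log units; beyond the scatter) shows that in this assay 4-aminophenyl on the sulfonyl sulfur does not match (pyridin-2-yl)amino. The step of a 1.2-fold lower number from compound 1 to compound 4 (0.07 log units; within the scatter) leaves 4-aminophenyl and amino on that sulfur without a clear order, so the lower number of compound 3 does not extend to compound 4. No supporting data explain the difference between these two groups.

From the compounds shown here alone, whether phenylamino on the sulfonyl sulfur would keep the number of compound 3 remains open. So does the contribution of the amine in 4-aminophenyl, which a plain phenyl group would test.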